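Acyl chain extension on the shared core

The source may hold more compounds than are shown below. What is called first, only, known or untested is meant among the compounds shown, and "the series" means these compounds.

Compound 2 `CCC(=O)n1nc(C)c(-c2ccc(Cl)c(Cl)c2)c1N` is the reference point. In an assay on Sf9 cells for inhibition of inhibitor of nuclear factor kappa-B kinase subunit epsilon (Homo sapiens), read by ADP-Glo, with a stated time of 60 min (on this read-out higher numbers stand for weaker inhibition and lower numbers for stronger inhibition), compound 2 gives only a limit of the assay, > 100000 nM. Compound 1 `CC(=O)n1nc(C)c(-c2ccc(Cl)c(Cl)c2)c1N` likewise returns only a limit in this assay, > 100000 nM. The step that the two limits leave unreadable from compound 1 to compound 2 stays unreadable since both values sit at the limit of > 100000 nM in this assay, at which 2 of the 2 values shown sit. Compound 3 `CCCC(=O)n1nc(C)c(-c2ccc(Cl)c(Cl)c2)c1N` carries the change (methyl in place of hydrogen on a saturated chain carbon, two bonds along the chain from a carbonyl carbon). For the measured compounds named here, the one measured step that bears on it, a step that the two limits leave unreadable from compound 1 to compound 2, adds the same unit to the same chain one bond closer to the carbonyl and yields no readable size. With both known values at the limit of > 100000 nM in this assay, at which 2 of the 2 values shown sit, there is no indication that growing this chain moves the series out of the unreadable region, so no change beyond the scatter is expected and the read-out will most probably be a limit again. Compound 3 is expected at 150000 nM, within 30000 nM to 1000000 nM, which corresponds to an expected step that the limit leaves unreadable from compound 2 to compound 3.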

Compound 3, half-maximal inhibitory concentration: > 100000 nM
Compound 3 ended at the assay's limit (the forecaster's own chance of this, stated with the estimate: 85%); the middle value lies beyond the limit too.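

No step among compound 1, compound 2 and compound 3 can be read, since each result is only a limit of the assay: the limit of > 100000 nM in this assay, at which 3 of the 3 values shown sit.

The compounds shown leave open whether any acyl chain on the shared core gives a readable value, and how chain length would then act.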